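A few compounds are considered here, and "the series" means these few. Any claim that something is new, unique, unknown or untested is made for them only; others in the source may bear on it.

Among the three compounds measured in a functional assay on EA.hy 926 cells (Homo sapiens) for cytotoxicity, read by MTT assay, with stated times of 24 h and 12 h, tested at 50 uM (a higher number here means a stronger effect of the compound at the concentration tested, a lower number a weaker effect), compound 2 `COc1ccc(/C=C/C(=O)O)cc1OC(=O)c1nc(C)c(C)nc1C` stands highest: in this assay compound 2 gives 160%. The nearest is compound 3 `CCOC(=O)/C=C/c1ccc(OC)c(OC(=O)c2nc(C)c(C)nc2C)c1`, which in this assay gives 89%, and the furthest is compound 1 `Cc1nc(C)c(C(=O)Oc2ccccc2/C=C/C(=O)O)nc1C`, which in this assay gives 64.9%; both gaps lie beyond the scatter.

Compound 4 `Cc1nc(C)c(C(=O)Oc2cccc(/C=C/C(=O)O)c2)nc1C` differs from compound 2 in one place: hydrogen in place of methoxy on an aromatic carbon.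

Going by the values given here, the only single-place step recorded, a number 71 percentage points lower from compound 2 to compound 3 (beyond the scatter), concerns ethyl in place of hydrogen on an oxygen next to a carbonyl group and does not touch the methoxy, so it does not bear on this change. Compound 1 also lacks a methoxy, but it differs from compound 2 in more than one place, so only its value can be read beside that of compound 2. Among the compounds with values here, with no step that speaks directly to removing the methoxy, a drop from the high value of compound 2 is expected, but with wide uncertainty. For compound 4 a value of 100% is estimated, between 55% and 150%, which is expected to mean a number 60 percentage points lower from compound 2 to compound 4 (beyond the scatter).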

Compound 4, a percentage reported as activity, at one concentration (the size of the read-out at that concentration, not a potency): 75.3%
Estimate against measurement, compound 4: 24.7 percentage points above; the range from low to high includes it.
By their numbers in this assay, from the lowest: compound 1; then compound 4; then compound 3; then compound 2.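

In this assay, going by these compounds alone, the methoxy on this aromatic carbon, para to a 2-carboxyethenyl group, now has a single-place step of its own: a number 84.7 percentage points lower from compound 2 to compound 4 (beyond the scatter), a large change from removing only this group. Compound 2 therefore loses much of its high number through a change at either of two separate places, since the ethyl change also gives a number 71 percentage points lower from compound 2 to compound 3 (beyond the scatter), so the high number of compound 2 is tied to both its methoxy and the hydrogen on its acid oxygen. No measurement here gives a reason for the drop at the methoxy position.

From the compounds shown here alone, whether a hydroxy group, an ethoxy group or a chlorine at this position would stay near compound 2 or fall towards compound 4 remains open. Also open, going by these compounds, is whether removing the methoxy from compound 3, which carries the ethyl group, would lower its number as well.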